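The source may hold more compounds than are shown below. What is called first, only, known or untested is meant among the compounds shown, and "the series" means these compounds.

Three compounds have a reading so far in a functional assay on U-937 cells (Homo sapiens) for antiproliferative activity, read by CCK-8 assay, with a stated time of 24 h; a higher number here means a weaker inhibitor, a lower number a stronger inhibitor. Compound 1 `CN(C)Cc1ccc2nc(NC(=O)N/N=C/c3ccccn3)sc2c1` gives 23200 nM in this test, and compound 2 `CN(C)Cc1ccc2nc(NC(=O)NN=C(c3ccccn3)c3ccccn3)sc2c1` gives 7800 nM in it. Compound 3 `CCN(CC)Cc1ccc(NC(=O)N/N=C(\C)c2ccccn2)cc1` is reported only as a limit, > 40000 nM, and not as an exact number.

Compound 4 `C/C(=N\NC(=O)Nc1ccc(CN2CCC(C)CC2)cc1)c1ccccn1` has yet to be measured. It differs from compound 3 in one group: 4-methylpiperidin-1-yl in place of diethylamino on a saturated chain carbon bound to an aromatic carbon. In words, 4-methylpiperidin-1-yl stands in place of diethylamino on a saturated chain carbon bound to an aromatic carbon, so that (diethylamino)methyl becomes (4-methylpiperidin-1-yl)methyl.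

Among the compounds with values here, no pair of measured compounds differs in this way, so the data give no direct guide to the size of the change. A modest step in this assay is expected, perhaps little beyond the usual scatter. The expected direction is slightly toward stronger inhibition, since compound 1 at 23200 nM shows that exact readings occur among these compounds. The estimated move is an at least 1.3-fold lower number from compound 3 to compound 4 (0.12 log units; that floor lies within the scatter), and it remains uncertain while compound 3 has only a limit. Compound 4 is expected to come in near 30000 nM, with an estimated range from 12000 nM to 60000 nM.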

Compound 4, half-maximal inhibitory concentration: > 40000 nM
Compound 4: no number, only a limit (the forecaster's own chance of this, stated with the estimate: 45%); at least 1.3-fold (0.12 log units) between middle value and limit.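

In this assay compound 4 is reported only as a limit, > 40000 nM, not as an exact number. Compound 3 is also reported only as a limit, so no step can be read between compound 3 and compound 4: the limit of > 40000 nM in this assay, at which 2 of the 4 values shown sit.

The compounds shown leave open whether 4-methylpiperidin-1-yl in place of diethylamino changes the reading at all, and in which direction.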